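The source may report more compounds than this note shows. Statements on the series, on what has been measured and on what is new or still open speak of the compounds shown alone.

In an in vitro assay on LLC-PK1 cells for displacement of a labelled ligand from growth hormone secretagogue receptor type 1 (Homo sapiens) (on this read-out higher numbers stand for weaker inhibition and lower numbers for stronger inhibition), compound 3 `CCc1ccc(Cn2c(CCc3ccccc3)nnc2[C@H](NC(=O)c2ccccn2)c2c[nH]c3ccccc23)cc1` gives 67 nM. Among the three compounds measured, compound 3 has the second highest number: compound 1 `COc1ccc(Cn2c(CCc3c[nH]c4ccccc34)nnc2[C@H](NC(=O)C(C)(C)N)c2c[nH]c3ccccc23)c(OC)c1` gives 108 nM, which is within the scatter of compound 3, while compound 2 `COc1ccc(Cn2c(CCc3ccccc3)nnc2[C@H](NC(=O)c2ccccn2)c2c[nH]c3ccccc23)c(OC)c1` gives 1.1 nM, far lower. Compound 4 `O=C(N[C@H](c1c[nH]c2ccccc12)c1nnc(CCc2ccccc2)n1-c1ccccc1)c1ccccn1` differs from compound 3 in one place: phenyl in place of 4-ethylbenzyl on an aromatic nitrogen. Within the data shown here, the only measured step that touches this position is the one from compound 2 to compound 3, where the group on the same aromatic nitrogen was exchanged and the number moved by a 61-fold higher number from compound 2 to compound 3 (1.78 log units; beyond the scatter), a large shift. That shows this position can matter a great deal, but it gives no direct guide to which way the change to phenyl will go. An expectation therefore rests on the sensitivity shown in that step, with a wide range. Compound 4 is expected to give about 150 nM, between 30 nM and 800 nM, which means an estimated step of a 2.2-fold higher number from compound 3 to compound 4 (0.35 log units; beyond the scatter).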

Compound 4, half-maximal inhibitory concentration: 105 nM
Compound 4: the middle estimate sits 1.4-fold (0.15 log units) above what was measured, within the range that was stated.
By their numbers in this assay, from the lowest: compound 2; then compounds 3, 4 and 1 (each within the scatter of the next).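

In this assay, phenyl in place of 4-ethylbenzyl on the aromatic nitrogen gives a 1.6-fold higher number from compound 3 to compound 4 (0.20 log units; within the scatter) and so stays within the scatter, even though this swap removes three carbon atoms. Phenyl in place of 2,4-dimethoxybenzyl at the same nitrogen gives a 95-fold higher number from compound 2 to compound 4 (1.98 log units; beyond the scatter) as a large step, so among the three groups compared here on this shared core, only 2,4-dimethoxybenzyl stands apart, while 4-ethylbenzyl and phenyl cannot be told apart. Nothing measured here explains why this one group stands apart. Still open, as far as these compounds go, is whether a single methoxy group, as in 2-methoxybenzyl or 4-methoxybenzyl, would be enough to reach a number close to that of compound 2. An unsubstituted benzyl group would also help to separate the effect of the chain carbon from that of the ring substituents.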